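Taking the chloro off compound 2

The compounds below may be only part of what the source reports. "The series", "measured", "known", "first", "only" and "open" are said of these compounds alone.

Compound 1 `Cc1ccc([C@@H](C)Oc2cc3onc(CCC(=O)O)c3cc2Cl)nn1`: 1.1 L/kg
Compound 2 `C[C@@H](Oc1cc2onc(CCC(=O)O)c2cc1Cl)c1ccc(Cl)cn1`: 0.26 L/kg

In an ADME assay on the whole organism (strain Han-Wistar) for pharmacokinetics, with Rattus norvegicus as the target, read by LC-MS, at a dose of 1 mg/kg by the intravenous route (on this read-out higher numbers stand for wider distribution into tissues and lower numbers for narrower distribution), compound 2 has the lower of the two numbers, 0.26 L/kg. Compound 3 `C[C@@H](Oc1cc2onc(CCC(=O)O)c2cc1Cl)c1ccccn1` has hydrogen in place of chloro on an aromatic carbon, turning 5-chloropyridin-2-yl into pyridin-2-yl: hydrogen in place of chloro on an aromatic carbon. Going by the values given here, only one measured step bears on this, and only loosely: a 4.2-fold lower number from compound 1 to compound 2 (0.63 log units; beyond the scatter). Among the compounds with values here, that step swaps 6-methylpyridazin-3-yl for 5-chloropyridin-2-yl, so it changes more than the chloro, and no measured pair isolates the chloro alone. Compound 1, which has no chloro, gives 1.1 L/kg, so a small rise is expected in this assay, smaller than that step and perhaps within the scatter. As a step, the estimate is a 1.6-fold higher number from compound 2 to compound 3 (0.21 log units; within the scatter). Compound 3 is expected at 0.42 L/kg, with an estimated range of 0.2 L/kg to 0.9 L/kg.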

Compound 3, volume of distribution at steady state in the Rattus norvegicus assay: 0.42 L/kg
For compound 3 middle estimate and measured number coincide at the digits printed; measured number inside the range.
By their numbers in the Rattus norvegicus assay, from the lowest: compounds 2 and 3 (each within the scatter of the next); then compound 1.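

Going by these compounds alone, with the chloro as the only change, the Rattus norvegicus assay gives a 1.6-fold higher number from compound 2 to compound 3 (0.21 log units; within the scatter), so compound 2 and compound 3 cannot be told apart on this read-out, and the chloro at this position makes no clear difference to distribution. The comparison of the two ring groups without the chloro still gives a 2.6-fold lower number from compound 1 to compound 3 (0.42 log units; beyond the scatter), so the gap to compound 1 goes with 6-methylpyridazin-3-yl against pyridin-2-yl rather than with the chloro alone. In a physicochemical assay for pharmacokinetics, at pH 6 (a higher number here means that the compound lasts longer, a lower number that the compound disappears faster), compound 2 gives > 1000 h as a limit of the assay and not a number. In the physicochemical assay compound 3 gives > 1000 h as a limit of the assay and not a number. Compound 2 and compound 3 both sit at a limit rather than at a number, so the step between them cannot be read: the limit of > 1000 h in the physicochemical assay, at which 2 of the 2 values shown sit.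

On these data alone, whether a nitrile or a methoxy group at this position would shift distribution beyond the scatter remains open. Also open, as far as these compounds go, is whether the methyl or the ring nitrogens of 6-methylpyridazin-3-yl account for the gap.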